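Undefined stereocentre to S form: expected clearance

The source may report more compounds than this note shows. Statements on the series, on what has been measured and on what is new or still open speak of the compounds shown alone.

Within the data shown here, in an ADME assay on microsomes from liver (Homo sapiens) for metabolic stability (on this read-out higher numbers stand for fast clearance and lower numbers for slow clearance), compound 1 `CC(C(=O)O)c1nn(Cc2cn3cc(OCC4CC4)c(Cl)cc3n2)c2ccccc2c1=O` gives 35 mL/min/kg and it holds the only exact number among the three compounds measured so far. Compound 2 `CCOc1cc2[nH]c(Cc3nn(CC(=O)O)c(=O)c4ccccc34)nc2cc1Cl` has < 15.2 mL/min/kg as its entry, which is a limit and not a number. Compound 3 `O=C(O)Cn1nc(Cc2cn3cc(OCC4CC4)c(Cl)cc3n2)c2ccccc2c1=O` has < 16.7 mL/min/kg as its entry, which is likewise a limit. Neither entry gives an exact gap to compound 1.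

The next compound to be read out is compound 4 `C[C@H](C(=O)O)c1nn(Cc2cn3cc(OCC4CC4)c(Cl)cc3n2)c2ccccc2c1=O` and it stays very close to compound 1. Between the two, the two compounds have the same atoms and bonds; at least one stereo element is drawn with a configuration in one of them and without one in the other: 1 of 1 stereo elements differ; a stereocentre at a saturated chain carbon is drawn without a configuration in compound 1 and S in compound 4 is the whole change, with a stereocentre at a saturated chain carbon drawn without a configuration in compound 1 and S in compound 4. The atoms and bonds stay the same. Among the measured compounds shown here, no measured pair in this set isolates a stereocentre, so the expectation rests on the structural change alone, with compound 1 at 35 mL/min/kg as its anchor. In this assay no step beyond the usual scatter is expected, and neither direction is favoured. The expected move is small, with a 1.1-fold lower number from compound 1 to compound 4 (0.03 log units; within the scatter) estimated to stay within that scatter. Compound 4 is expected to read about 33 mL/min/kg with an estimated range of 18 mL/min/kg to 60 mL/min/kg on this read-out.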

Compound 4, clearance: < 15 mL/min/kg
Compound 4: a limit, no number; the forecaster's own chance of this, stated with the estimate: 10%; middle value at least 2.2-fold (0.34 log units) from the limit.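

In this assay, among these compounds, the change at the stereocentre gives an at least 2.3-fold lower number from compound 1 to compound 4 (0.36 log units; beyond the scatter), and this is the only pair in the set that isolates a stereocentre. Compound 4 gives < 15 mL/min/kg, which is a limit of the assay and not a number, so the step fixes only a minimum size and no exact gap. The atoms and bonds stay the same, so a step beyond the scatter can here go with a difference in stereo drawing alone, which the earlier compounds could not show, and the only structural difference that goes with it is this: the fact that one of compounds 1 and 4 is drawn with a defined configuration and the other without, at the place where they differ

The compounds shown leave open how the R form at this stereocentre reads in this assay, and what composition lies behind the undefined drawing of compound 1. They also leave open whether a longer chain at the same saturated chain carbon, or an amide in place of the carboxylic acid, would keep clearance on this read-out as low as it is in compound 4.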